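The compounds below may be only part of what the source reports. "The series", "measured", "known", "first", "only" and "open" are said of these compounds alone.

Measured compounds:
- Compound 1, `CC(=O)Nc1cccc2c(-c3cccc(NC(=O)c4ccc(Cl)c(C(F)(F)F)c4)c3)ccnc12`: 2700 nM
- Compound 2, `Nc1cccc2c(-c3cccc(NC(=O)Nc4cc(C(F)(F)F)cc(C(F)(F)F)c4)c3)ccnc12`: 1500 nM

Both compounds were tested in a functional assay on MDA-MB-435 cells (Homo sapiens) for antiproliferative activity, read by sulforhodamine B assay, with a stated time of 48 h; on this read-out higher numbers stand for weaker inhibition and lower numbers for stronger inhibition. Among the measured compounds shown here, on this read-out compound 2 gives 1500 nM, the lower of the two numbers so far, while compound 1 gives 2700 nM. The gap between these two values lies within the usual scatter of repeated measurements, so the two compounds cannot be told apart on these numbers alone.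

Compound 3, `CC(=O)Nc1cccc2c(-c3cccc(NC(=O)Nc4cc(C(F)(F)F)cc(C(F)(F)F)c4)c3)ccnc12`, has not yet been measured in this assay. It differs from compound 2 in one place: acetyl in place of hydrogen on a nitrogen on an aromatic ring. Compound 1 already carries the acetamido group on the same part of the shared core, but it is joined to a different linker, so no direct comparison of this one change is available among the measured compounds.

Given that, the step from compound 2 to compound 3 is expected to be small, most likely within the scatter, with a slight lean toward a higher number, as a 1.3-fold higher number from compound 2 to compound 3 (0.12 log units; within the scatter). For compound 3 the estimated value is 2000 nM, with a plausible range from 800 nM to 5000 nM.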

Compound 3, half-maximal inhibitory concentration: 15300 nM
For compound 3 the middle estimate is 7.7-fold (0.88 log units) below the measured one; measured number outside the range, above it.
By their numbers in this assay, from the lowest: compounds 2 and 1 (each within the scatter of the next); then compound 3.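

In this assay, replacing hydrogen with acetyl on the nitrogen, which turns the amino group into an acetamido group, gives a 10-fold higher number from compound 2 to compound 3 (1.01 log units; beyond the scatter). Among the compounds shown here, this is the first direct reading of this single change, as compounds 1 and 2 differ in more than one place, and it shows that the read-out is sensitive to what sits on this nitrogen when the rest of compound 2 stays the same. Nothing available explains why inhibition weakens with this change, so the step stands as an observation only.

Going by these compounds, with only one replacement on this nitrogen, it remains open whether the loss belongs to the acetyl group in particular or would also follow from a smaller or larger group there, such as a methyl group or a longer acyl chain like butyryl. On these data alone, it is also open how large the same step would be with the different linker of compound 1, where an amino counterpart of that compound would provide the matching comparison.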